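This account rests on a few compounds, and the source may have more. Where it says the series, first, only, none or still open, it means among the compounds named here.

Measured so far:
- compound 1, `COc1cc(-c2nn(-c3cccc(NC(=O)Nc4ccc(Cl)c(Cl)c4)c3)cc2-c2ccncc2)ccc1Cl`: 940 nM in a functional assay on MDA-MB-435 cells (Homo sapiens) for inhibition, read by sulforhodamine B assay, with a stated time of 48 h; on this read-out higher numbers stand for weaker inhibition and lower numbers for stronger inhibition
- compound 2, `COc1cc(-c2nn(-c3cccc(NC(=O)c4ccc(Cl)c(C(F)(F)F)c4)c3)cc2-c2ccncc2)ccc1Cl`: 660 nM in this assay

Among the measured compounds shown here, compound 2 gives the lowest of the two numbers so far, but the gap to compound 1 is small: a 1.4-fold lower number from compound 1 to compound 2 (0.15 log units; within the scatter). Compound 3, `COc1cc(-c2nn(-c3cccc(NC(=O)Nc4ccc(Cl)c(C(F)(F)F)c4)c3)cc2-c2ccncc2)ccc1Cl`, is not yet measured. It differs from compound 2 by (4-chloro-3-(trifluoromethyl)phenyl)amino in place of 4-chloro-3-(trifluoromethyl)phenyl on a carbonyl carbon, so the amide of compound 2 becomes a urea while the aryl group is kept. For the measured compounds named here, the only step on record, a 1.4-fold lower number from compound 1 to compound 2 (0.15 log units; within the scatter), swapped urea for amide together with the aryl and stayed within the scatter. No step beyond the scatter is therefore expected here: compound 3 is estimated at 800 nM (range 350 nM to 1800 nM), a step of a 1.2-fold higher number from compound 2 to compound 3 (0.08 log units; within the scatter).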

Compound 3, half-maximal inhibitory concentration: 680 nM
Compound 3: the middle estimate sits 1.2-fold (0.07 log units) above what was measured, within the range that was stated.
By their numbers in this assay, from the lowest: compounds 2, 3 and 1 (each within the scatter of the next).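

In this assay, the carbonyl linker can now be read alone: with 4-chloro-3-(trifluoromethyl)phenyl kept, changing the amide to a urea gives a small step (a 1.0-fold higher number from compound 2 to compound 3 (0.01 log units; within the scatter)). The aryl substituent can also be read alone: with the urea kept, trifluoromethyl in place of chloro gives a similarly small step (a 1.4-fold lower number from compound 1 to compound 3 (0.14 log units; within the scatter)). No measurement bears on the reason for these results. From the compounds shown here alone, it remains open whether a cyclohexyl group or a longer alkyl chain on the carbonyl carbon would keep the number in this range. Also open, going by these compounds, is whether an amine or a carboxylic acid in place of trifluoromethyl would change it.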